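The source may report more compounds than this note shows. Statements on the series, on what has been measured and on what is new or still open speak of the compounds shown alone.

Of the compounds shown here, two built on the same core have been tested in a functional assay on HT-29 cells (Homo sapiens) for cytotoxicity, read by MTT assay, with a stated time of 72 h; a higher number here means a weaker inhibitor, a lower number a stronger inhibitor. Compound 1 `O=C1N/C(=N/c2csc(-c3ccc(Cl)cc3)c2)S/C1=C\c1ccc(Br)cc1` gives 2000 nM in this assay. Among the compounds with values here, compound 2 `COc1ccc(/C=C2\S/C(=N\c3csc(-c4ccc(Cl)cc4)c3)NC2=O)cc1OC` gives 10900 nM in this assay, the higher of the two numbers, and the single measured step, a 5.5-fold higher number from compound 1 to compound 2 (0.74 log units; beyond the scatter), is what separates it from its only neighbour. Compound 3 `O=C1N/C(=N/c2csc(-c3ccc(Cl)cc3)c2)S/C1=C\c1ccc(F)cc1` differs from compound 2 in one place: 4-fluorophenyl in place of 3,4-dimethoxyphenyl on a double-bonded chain carbon bound to a double-bonded ring carbon. Within the data shown here, the only measured step that bears on this change is a 5.5-fold higher number from compound 1 to compound 2 (0.74 log units; beyond the scatter), in which a 3,4-dimethoxyphenyl replaced a 4-bromophenyl at the same place. Among the measured compounds shown here, the change to compound 3 undoes that replacement, but with a fluorine rather than a bromine, and no measured step shows how those two compare here; a downward step of roughly that size is nonetheless expected, a 3.6-fold lower number from compound 2 to compound 3 (0.56 log units; beyond the scatter). Compound 3 is therefore estimated at 3000 nM in this assay, with a range from 1000 nM to 10000 nM.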

Compound 3, half-maximal inhibitory concentration: 4100 nM
For compound 3 the middle estimate is 1.4-fold (0.14 log units) below the measured one; the measured number falls inside the stated range.
By their numbers in this assay, from the lowest: compound 1; then compound 3; then compound 2.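

In this assay the choice of halogen on this phenyl ring now matters: fluoro in place of bromo on an aromatic carbon gives a 2.1-fold higher number from compound 1 to compound 3 (0.31 log units; beyond the scatter) and this modest step lies beyond the scatter. Replacing the 3,4-dimethoxyphenyl with 4-fluorophenyl gives a 2.7-fold lower number from compound 2 to compound 3 (0.42 log units; beyond the scatter), so both halogen-bearing rings have lower numbers than the 3,4-dimethoxyphenyl ring, but they do not match each other. No measurement here explains this order.

As far as these compounds go, it remains open whether a ring carrying chlorine, a single methoxy group or no substituent at all would fit between these values. A phenyl ring carrying an amine or a carboxylic acid on the same double-bonded chain carbon is also untested among the compounds shown, so the effect of such groups is unknown.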